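Ethyl in place of 1H-pyrrol-2-yl under assay limits

The source may hold more compounds than are shown below. What is called first, only, known or untested is meant among the compounds shown, and "the series" means these compounds.

In an ADME assay on MDCK cells (Canis lupus familiaris) for cytotoxicity, read by MTT assay, with a stated time of 24 h (a lower number here means that less compound is tolerated, a higher number that more compound is tolerated), compound 1 `N#CCCN(Cc1ccco1)S(=O)(=O)c1ccc(Br)cc1` gives > 180000 nM, which is a limit of the assay and not a number. Compound 2 `N#CCCN(Cc1ccc[nH]1)S(=O)(=O)c1ccc(Br)cc1` gives > 181000 nM, which is likewise only a limit. For the measured compounds named here, compound 2 therefore has no measured number of its own, and the one value beside it offers none either.

Compound 3 `CCCN(CCC#N)S(=O)(=O)c1ccc(Br)cc1` has not yet been measured. It carries ethyl in place of 1H-pyrrol-2-yl on a saturated chain carbon bound to a sulfonamide nitrogen, and the counted difference is ethyl in place of 1H-pyrrol-2-yl on a saturated chain carbon bound to a sulfonamide nitrogen. Going by the values given here, the only measured step at this place is a step that the two limits leave unreadable from compound 1 to compound 2, an exchange of furan-2-yl for 1H-pyrrol-2-yl. It gives no readable size to carry forward, and it shows no sign of a change in this assay.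

No step beyond the scatter is therefore expected, and no direction can be named, so the expected step is a step that the limit leaves unreadable from compound 2 to compound 3. For compound 3 the estimate is 190000 nM, with an expected range from 100000 nM to 300000 nM, and the result may well be reported again as a limit.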

Compound 3, half-maximal cytotoxic concentration: 116000 nM
The estimate for compound 3 lay 1.6-fold (0.21 log units) above the measured number; low and high end bracket the measured number.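

In this assay, for the compounds shown here, compound 3, with ethyl on a saturated chain carbon bound to a sulfonamide nitrogen, gives 116000 nM, the first real number at this place rather than a limit of the assay. Replacing 1H-pyrrol-2-yl with ethyl gives an at least 1.5-fold lower number from compound 2 to compound 3 (0.19 log units; that floor lies within the scatter), and replacing furan-2-yl with ethyl gives an at least 1.5-fold lower number from compound 1 to compound 3 (0.19 log units; that floor lies within the scatter), so both steps can now be read at least as floors, although neither floor passes the scatter. The step from the pyrrole compound stays a floor because compound 2 has only a limit and not a number: the limit of > 181000 nM in this assay, at which 1 of the 3 values shown sits.

The step from the furan compound is bounded in the same way, and the step between the two ring compounds still cannot be read, since compound 1 also has only a limit: the limit of > 180000 nM in this assay, at which 1 of the 3 values shown sits. The compounds shown leave open how far the ring compounds really lie from compound 3, and what a longer chain such as butyl, or a primary amine, would give at this place in this assay.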